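A few compounds are considered here, and "the series" means these few. Any claim that something is new, unique, unknown or untested is made for them only; others in the source may bear on it.

Measured compounds in a physicochemical assay, read by spectrophotometry, with a stated time of 30 min; on this read-out higher numbers stand for weaker inhibition and lower numbers for stronger inhibition:
- compound 1 `COc1cc(/C=N/NC(=O)CCCc2nc3ccccc3c(=O)[nH]2)cc(OC)c1OC` gives 106000000 nM
- compound 2 `COc1cc(/C=N/NC(=O)CCCc2nc3ccccc3c(=O)[nH]2)cc(OC)c1O` gives 97000000 nM
- compound 3 `COc1ccc(/C=N/NC(=O)CCCc2nc3ccccc3c(=O)[nH]2)cc1` gives 247000000 nM

Compound 1 and compound 2 share a core and differ by hydrogen in place of methyl on an oxygen on an aromatic ring; that change gave a 1.1-fold lower number from compound 1 to compound 2 (0.04 log units; within the scatter). Compound 3 carries a different core; the difference between the two cores is not broken down here. In this assay compound 3 stands highest of the three, beyond the scatter from both compound 1 and compound 2.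

Compound 4 `O=C(CCCc1nc2ccccc2c(=O)[nH]1)N/N=C/c1ccc(O)cc1` is not yet measured. It differs from compound 3 by hydrogen in place of methyl on an oxygen on an aromatic ring, the same change as that from compound 1 to compound 2, at the same kind of place. Given the step seen from compound 1 to compound 2, compound 4 is expected to sit close to compound 3, with an expected step of a 1.1-fold lower number from compound 3 to compound 4 (0.03 log units; within the scatter). The estimate for compound 4 in this assay is 230000000 nM, between 120000000 nM and 450000000 nM.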

Compound 4, half-maximal inhibitory concentration: 214000000 nM
Compound 4: the middle estimate sits 1.1-fold (0.03 log units) above what was measured, and the stated range covers the measured number.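

In this assay, among these compounds, the replacement of methoxy by hydroxy gives a 1.2-fold lower number from compound 3 to compound 4 (0.06 log units; within the scatter) and, on the core of compound 1, gives a 1.1-fold lower number from compound 1 to compound 2 (0.04 log units; within the scatter); both steps lie within the scatter, so in these two pairs the replacement carries from one core to the other with no step that can be told from repeat measurement. This rests on two pairs only and does not show a rule for the series or for other cores. No measurement available here bears on why the members of each pair read alike.

Open, as far as these compounds go, is whether an amine or a carboxylic acid in place of the hydroxy would read differently in this assay. Also open, from the compounds shown here alone, is whether a longer chain on that oxygen would stay within the scatter.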